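Fluoro on the triazole phenyl with a methylpiperazine tail

The source may hold more compounds than are shown below. What is called first, only, known or untested is meant among the compounds shown, and "the series" means these compounds.

In a functional assay on NCI-H460 cells (Homo sapiens) for cytotoxicity, read by MTT assay, with a stated time of 72 h (on this read-out lower numbers stand for stronger inhibition and higher numbers for weaker inhibition), compound 3 `COc1cc2c(Oc3ccc(NC(=O)c4cn(-c5ccccc5)nn4)cc3F)ccnc2cc1OCCCN1CCN(C)CC1` gives 200 nM. Compound 1 `COc1cc2c(Oc3ccc(NC(=O)c4cn(-c5ccccc5F)nn4)cc3F)ccnc2cc1OCCCN1CCCCC1` gives 210 nM and compound 2 `COc1cc2c(Oc3ccc(NC(=O)c4cn(-c5ccccc5F)nn4)cc3F)ccnc2cc1OCCCN1CCC(C)CC1` gives 190 nM, so compound 3 sits with both inside the scatter. The step to compound 4 `COc1cc2c(Oc3ccc(NC(=O)c4cn(-c5ccccc5F)nn4)cc3F)ccnc2cc1OCCCN1CCN(C)CC1` is fluoro in place of hydrogen on an aromatic carbon. Within the data shown here, no measured pair shows this change directly; the only measured step, a 1.1-fold lower number from compound 1 to compound 2 (0.04 log units; within the scatter), touches the saturated tail ring and not the aromatic ring, while compounds 1 and 2 carry the 2-fluorophenyl group of compound 4 at numbers close to that of compound 3. In this assay no step beyond the scatter is therefore expected. The expected step is no change at the digits printed from compound 3 to compound 4 (within the scatter). Compound 4 is estimated at 200 nM in this assay, within 100 nM to 400 nM.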

Compound 4, half-maximal inhibitory concentration: 230 nM
Compound 4: the middle estimate sits 1.2-fold (0.06 log units) below what was measured, within the range that was stated.
By their numbers in this assay, from the lowest: compounds 2, 3, 1 and 4 (each within the scatter of the next).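

In this assay, 2-fluorophenyl in place of phenyl can now be read directly, as a 1.2-fold higher number from compound 3 to compound 4 (0.06 log units; within the scatter). With the 2-fluorophenyl group held, 4-methylpiperazin-1-yl on the chain gives a 1.2-fold higher number from compound 2 to compound 4 (0.08 log units; within the scatter) against 4-methylpiperidin-1-yl, and a 1.1-fold higher number from compound 1 to compound 4 (0.04 log units; within the scatter) against piperidin-1-yl, so neither the fluoro nor these tails separate the four compounds. No measurement at hand offers an explanation for these steps. Going by these compounds, whether methoxy or trifluoromethyl on that aromatic carbon, or morpholine on the chain, would move the number stays open.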